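This account rests on a few compounds, and the source may have more. Where it says the series, first, only, none or still open, it means among the compounds named here.

Compound 1 `O=C(CN1CCC(c2cccc[n+]2[O-])CC1)Nc1cccc(Cl)c1` gives the largest maximal response of the two compounds tested in a functional assay on HEK293 cells for agonist activity at D(4) dopamine receptor (Homo sapiens), read by FLIPR (a higher number here means a larger maximal response, a lower number a smaller maximal response), reaching 76%. Among the measured compounds shown here, its nearest neighbour, compound 2 `Cc1ccc(Cl)cc1NC(=O)CN1CCC(c2cccc[n+]2[O-])CC1`, reaches 58% in this assay, and the only measured step between the two, a number 18 percentage points lower from compound 1 to compound 2 (beyond the scatter), comes from a methyl in place of hydrogen on an aromatic carbon.

Compound 3 `O=C(CN1CCC(c2cccc[n+]2[O-])CC1)Nc1cccc(-c2ccccc2)c1` differs from compound 1 by phenyl in place of chloro on an aromatic carbon. For the measured compounds named here, no measured step covers phenyl in place of chloro, so the one step on record, a modest drop for a different group at a different place, is only a rough guide that a change on this ring can lower the response. A small to modest decrease in this assay is therefore expected, though a result within the usual scatter would not surprise. Compound 3 is estimated to reach 64%, between 44% and 84%, meaning an expected step of a number 12 percentage points lower from compound 1 to compound 3 (beyond the scatter).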

Compound 3, largest response reached (reported as efficacy), in percent of the reference or control that the assay uses: 75%
The estimate for compound 3 lay 11 percentage points below the measured number; the range from low to high includes it.
By their numbers in this assay, from the lowest: compound 2; then compounds 3 and 1 (each within the scatter of the next).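

In this assay phenyl in place of chloro gives a number 1 percentage points lower from compound 1 to compound 3 (within the scatter) even though the group grows from 1 heavy atom to 6 heavy atoms and brings in a whole aromatic ring. Among the compounds shown here, this position on the aromatic ring therefore accepts a much larger group with no measurable loss of maximal response, something the single earlier step, a methyl change, could not show. Nothing on record explains why the response holds.

From the compounds shown here alone, with only chloro and phenyl seen here, it remains open whether this position would also accept an amine, a carboxylic acid or a longer chain. Going by these compounds, it is equally open whether plain hydrogen at this place would keep the response, and so whether either group contributes to it at all.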